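Weak cytotoxicity across a small quinazoline-type series

This account rests on a few compounds, and the source may have more. Where it says the series, first, only, none or still open, it means among the compounds named here.

Measured compounds:
compound 1, `Fc1cccc(-c2nc(Nc3ccc(Cl)cc3)c3cc(F)ccc3n2)c1`, 40300 nM
compound 2, `Fc1cccc(-c2nc(Nc3ccccc3Cl)c3cc(F)ccc3n2)c1`, > 50000 nM
compound 3, `Nc1ccccc1Nc1nc(-c2cccc(F)c2)nc2ccc(F)cc12`, > 50000 nM

In a functional assay on HT29-AK cells (Homo sapiens) for cytotoxicity, read by MTT assay, with a stated time of 48 h (on this read-out higher numbers stand for weaker inhibition and lower numbers for stronger inhibition), compound 1 gives 40300 nM. For compound 2 the assay reports only a limit, > 50000 nM. For compound 3 the assay likewise reports only a limit, > 50000 nM. Compound 2 therefore stands at the edge of what the assay can read, and because the limit of > 50000 nM in this assay, at which 2 of the 3 values shown sit, the comparison between compound 2 and compound 3 stays unreadable, a step that the two limits leave unreadable from compound 2 to compound 3.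

Compound 4, `Cc1ccc(Nc2nc(-c3cccc(F)c3)nc3ccc(F)cc23)cc1`, is not yet measured. It differs from compound 2 by 4-methylphenyl in place of 2-chlorophenyl on a nitrogen on an aromatic ring. Among the measured compounds shown here, the one measured step that bears on this change is the move from a 4-chlorophenyl to a 2-chlorophenyl, an at least 1.2-fold higher number from compound 1 to compound 2 (0.09 log units; that floor lies within the scatter), which went from a weak number to a limit; the step of an at least 1.2-fold higher number from compound 1 to compound 3 (0.09 log units; that floor lies within the scatter) also ended at a limit. Compound 4 returns a group to the 4-position of the phenyl, so compound 4 is expected to sit near compound 1, with an estimated 45000 nM (range 20000 nM to 100000 nM). From compound 2 this is expected to read as an at least 1.1-fold lower number from compound 2 to compound 4 (0.04 log units; that floor lies within the scatter), a step that may well remain beyond what the assay can resolve.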

Compound 4, half-maximal inhibitory concentration: > 50000 nM
Compound 4 gave a limit, no number; the forecaster's own chance of this, stated with the estimate: 50%; at least 1.1-fold (0.04 log units) between middle value and limit.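

The 4-methylphenyl on the nitrogen shows that a group at the 4-position of that phenyl is not enough to give a readable number, since only the 4-chlorophenyl of compound 1 has done so among the four compounds. The exchange of the chloro for a methyl reads as an at least 1.2-fold higher number from compound 1 to compound 4 (0.09 log units; that floor lies within the scatter), so this single change does not establish a real loss of cytotoxicity in this assay, and compound 1 itself may differ little from the other three. The steps to compound 4 from compound 2 and from compound 3 cannot be read, and the choice between 2-chlorophenyl, 2-aminophenyl and 4-methylphenyl stays unranked, because all three compounds rest at the same limit: the limit of > 50000 nM in this assay, at which 3 of the 4 values shown sit.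

On these data alone, how far compound 2, compound 3 and compound 4 lie past that limit remains unknown, as does whether any change on this nitrogen can bring the series to clearly stronger inhibition. A carboxylic acid or a morpholine on that phenyl ring, or a longer chain in its place, would test whether this position can move the read-out at all.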